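Methylation of the ring amine in compound 3

The source may report more compounds than this note shows. Statements on the series, on what has been measured and on what is new or still open speak of the compounds shown alone.

Compound 3 `c1ccc(OCc2nc3c(OCCCN4CCCCC4)cccc3n2CCCC2CCNCC2)cc1` stands highest of the three numbers in an in vitro assay on AV12 cells for binding affinity to Neuropeptide Y receptor type 1 (Homo sapiens) (a higher number here means a weaker inhibitor, a lower number a stronger inhibitor), giving 4.5 nM. Compound 1 `c1ccc(OCc2nc3c(OCCCN4CCCCC4)cccc3n2CCCC2CCN(CCC3CCCCC3)CC2)cc1` gives 0.285 nM and compound 2 `C=CCCN1CCC(CCCn2c(COc3ccccc3)nc3c(OCCCN4CCCCC4)cccc32)CC1` gives 0.707 nM. The step to compound 4 `CN1CCC(CCCn2c(COc3ccccc3)nc3c(OCCCN4CCCCC4)cccc32)CC1` is methyl in place of hydrogen on an amine nitrogen in a ring. Within the data shown here, the steps that bear on it are those at the same nitrogen: a 16-fold higher number from compound 1 to compound 3 (1.20 log units; beyond the scatter) and a 6.4-fold higher number from compound 2 to compound 3 (0.80 log units; beyond the scatter), both showing that removing the substituent from this amine nitrogen raised the number; a 2.5-fold higher number from compound 1 to compound 2 (0.39 log units; beyond the scatter) shows the larger of the two groups gave the lower number. Methyl, with its one heavy atom, is the smallest group tried here, so for compound 4 a lowering in this assay that stays short of the but-3-en-1-yl step is expected: a 2.5-fold lower number from compound 3 to compound 4 (0.40 log units; beyond the scatter). Compound 4 is therefore estimated at 1.8 nM, range 0.7 nM to 4.5 nM.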

Compound 4, inhibition constant: 1.62 nM
Compound 4: the middle estimate sits 1.1-fold (0.05 log units) above what was measured; measured number inside the range.
By their numbers in this assay, from the lowest: compound 1; then compound 2; then compound 4; then compound 3.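

In this assay, a single methyl on the ring amine nitrogen is enough to give a step beyond the scatter: a 2.8-fold lower number from compound 3 to compound 4 (0.44 log units; beyond the scatter). The larger substituents still give lower numbers, as a 2.3-fold higher number from compound 2 to compound 4 (0.36 log units; beyond the scatter) and a 5.7-fold higher number from compound 1 to compound 4 (0.75 log units; beyond the scatter) show, so the order at this nitrogen follows substituent size across these four compounds, with none against it. Nothing measured here accounts for these steps. The compounds shown leave open whether benzyl or acetyl on this nitrogen would fit that order, and whether a hydroxyl at the end of the chain would change it.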